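A few compounds are considered here, and "the series" means these few. Any claim that something is new, unique, unknown or untested is made for them only; others in the source may bear on it.

Measured so far:
- compound 1, `Nc1scc(CN2CCN(c3cc(Cl)cc(Cl)c3)CC2)c1C(=O)c1ccc(Cl)cc1`: in a functional assay on CHO cells with adenosine receptor A1 (Homo sapiens) as the target, read by cAMP accumulation and immunoassay, with a stated time of 6 min, tested at 10 uM (on this read-out higher numbers stand for a weaker effect at the one concentration tested and lower numbers for a stronger effect), compound 1 gives -74%
- compound 2, `Nc1scc(CN2CCN(c3ccc(Cl)c(C(F)(F)F)c3)CC2)c1C(=O)c1ccc(Cl)cc1`: compound 2 gives -60%
- compound 3, `Nc1scc(CN2CCN(c3cccc4ccccc34)CC2)c1C(=O)c1ccc(Cl)cc1`: compound 3 gives -21%

Compound 1 holds the lowest number of the three in this assay; compound 2 is its nearest neighbour, by a number 14 percentage points higher from compound 1 to compound 2 (beyond the scatter), and compound 3 lies furthest away, by a number 53 percentage points higher from compound 1 to compound 3 (beyond the scatter). Between the other two, a number 39 percentage points higher from compound 2 to compound 3 (beyond the scatter).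

The unmeasured compound 4, `Nc1scc(CN2CCN(c3ccccc3F)CC2)c1C(=O)c1ccc(Cl)cc1`, differs from compound 1 in one place: 2-fluorophenyl in place of 3,5-dichlorophenyl on an amine nitrogen in a ring. Every measured step here swaps the aryl group on the same ring nitrogen, so all three bear on this case. Each of them raised the number on leaving 3,5-dichlorophenyl, modestly in a number 14 percentage points higher from compound 1 to compound 2 (beyond the scatter) and by a large amount in a number 53 percentage points higher from compound 1 to compound 3 (beyond the scatter). On that basis a rise from compound 1 to compound 4 is expected, probably of moderate size, since 2-fluorophenyl keeps a single six-membered carbon ring like the other substituted phenyl groups; the step is estimated as a number 34 percentage points higher from compound 1 to compound 4 (beyond the scatter). Compound 4 is therefore expected to give about -40% in this assay, within a range from -70% to -5%.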

Compound 4, a percentage reported as activity, at one concentration (the size of the read-out at that concentration, not a potency): -15%
The estimate for compound 4 lay 25 percentage points below the measured number, and the stated range covers the measured number.
By their numbers in this assay, from the lowest: compound 1; then compound 2; then compounds 3 and 4 (each within the scatter of the next).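

Read in this assay, the change to 2-fluorophenyl is large (a number 59 percentage points higher from compound 1 to compound 4 (beyond the scatter)) and nearly as large from the other chlorine-bearing aryl group (a number 45 percentage points higher from compound 2 to compound 4 (beyond the scatter)), so a single six-membered aromatic ring of carbon only on this ring nitrogen does not by itself keep the number near those of compound 1 and compound 2. Compound 4 instead stands level with the naphthalen-1-yl compound (a number 6 percentage points higher from compound 3 to compound 4 (within the scatter)), which means that two quite different aryl groups give the same reading here, and among these four compounds the two lowest numbers belong to the aryl groups that carry chlorine, with no compound going against that. Nothing available explains why this position responds in this way.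

As far as these compounds go, it remains open whether chlorine itself, the number of substituents on the phenyl ring or their placement sets the reading, a question that 2-chlorophenyl and 3,5-difluorophenyl groups on the same ring nitrogen would help to separate. From the compounds shown here alone, how an unsubstituted phenyl group or a pyridyl ring would read at this position also stays open.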